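Aryl urea hydrazones: cytotoxicity notes and a chloro analogue

A few compounds are considered here, and "the series" means these few. Any claim that something is new, unique, unknown or untested is made for them only; others in the source may bear on it.

The series shares a core carrying a triazole with a dimethylaminoethyl chain, a diaryl ether and an acyl hydrazone; the analogues differ only in the aryl ring of the hydrazone. Going by the values given here, compound 1 `CN(C)CCn1cnnc1-c1cc(Oc2ccc(NC(=O)N/N=C/c3cc(C(C)(C)C)cc(C(C)(C)C)c3O)cc2F)ccn1` is the single member with a number in an ADME assay on WI-38 cells (Homo sapiens) for cytotoxicity, read by MTT assay, with a stated time of 72 h; on this read-out lower numbers stand for stronger inhibition and higher numbers for weaker inhibition: in this assay compound 1 gives 2350 nM. Compound 2 `CN(C)CCn1cnnc1-c1cc(Oc2ccc(NC(=O)N/N=C/c3ccccc3)cc2F)ccn1`, the unsubstituted phenyl analogue, stands without a number, with the result given as "not determined" (no result reported). Compound 3 `COc1cc(/C=N/NC(=O)Nc2ccc(Oc3ccnc(-c4nncn4CCN(C)C)c3)c(F)c2)cc(OC)c1OC`, the trimethoxyphenyl analogue, is likewise given as "not determined" (no result reported). Among the compounds with values here, no step between measured compounds can therefore be drawn, and compound 2 cannot be placed against compound 1 on any number.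

Compound 4 `CN(C)CCn1cnnc1-c1cc(Oc2ccc(NC(=O)N/N=C/c3ccc(Cl)cc3)cc2F)ccn1` is the next analogue to be measured. Relative to compound 2, the change is chloro in place of hydrogen on an aromatic carbon. With no number for compound 2 and only compound 1 measured, no step beyond the usual scatter is expected in this assay between compound 2 and compound 4; the expectation rests on compound 1 alone. Compound 4 is therefore estimated to give roughly 3000 nM in this assay, with a likely range from 800 nM to 12000 nM.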

Compound 4, half-maximal inhibitory concentration: 1870 nM
Compound 4: the middle estimate sits 1.6-fold (0.21 log units) above what was measured; the range from low to high includes it.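

Going by these compounds alone, compound 4 gives 1870 nM in this assay but compound 2 has no single number there, so no step from compound 2 to compound 4 can be read. Nothing available bears on this result. The compounds shown leave open whether phenyl to 4-chlorophenyl shifts cytotoxicity at all in this series.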